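Compound 4 and the bis(3-aminopropyl)amino change

A few compounds are considered here, and "the series" means these few. Any claim that something is new, unique, unknown or untested is made for them only; others in the source may bear on it.

In a toxicity assay on CHO cells (Cricetulus griseus) for cytotoxicity, read by WST assay, with a stated time of 24 h (on this read-out lower numbers stand for stronger inhibition and higher numbers for weaker inhibition), compound 1 (`CC(C)=CCC/C(C)=C\CCC(C)=CCNCCN`) gives 32300 nM as its number, compound 2 (`CC(C)=CCC/C(C)=C\CCC(C)=CCNCCCCN`) gives 18100 nM and compound 3 (`CC(C)=CCC/C(C)=C\CCC(C)=CCNCCCCCN`) gives 38400 nM on the same read-out. For the measured compounds named here, compound 3 thus sits on the high side of this small set, clear of only one neighbour, and modestly: the step of a 2.1-fold higher number from compound 2 to compound 3 (0.33 log units; beyond the scatter) is the single one beyond the scatter, whereas a 1.2-fold higher number from compound 1 to compound 3 (0.08 log units; within the scatter) and a 1.8-fold lower number from compound 1 to compound 2 (0.25 log units; within the scatter) are not.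

Compound 4 (`CC(C)=CCC/C(C)=C\CCC(C)=CCNCCCN(CCCN)CCCN`) departs further, with bis(3-aminopropyl)amino in place of 2-aminoethyl on a saturated chain carbon, three bonds along the chain from an amine nitrogen as its change. Going by the values given here, no measured step brings in bis(3-aminopropyl)amino, so the three steps bear on it only loosely. Even the largest of them, a 2.1-fold higher number from compound 2 to compound 3 (0.33 log units; beyond the scatter) in size, gives no support for a dramatic shift. A small move toward a lower number is therefore expected, and the estimated step is a 1.5-fold lower number from compound 3 to compound 4 (0.19 log units; within the scatter) with its direction only weakly held. In this assay compound 4 is expected at 25000 nM with a range from 9000 nM to 70000 nM as the estimate.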

Compound 4, half-maximal inhibitory concentration: > 150000 nM
Compound 4: no number, only a limit; the forecaster's own chance of this, stated with the estimate: 15%; at least 6.0-fold (0.77 log units) between middle value and limit.
By their numbers in this assay, from the lowest: compounds 2, 1 and 3 (each within the scatter of the next, the first and the last beyond it). At a limit, above all of these: compound 4.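

Compound 4 gives only a limit in this assay, not a number: the limit of > 150000 nM in this assay, at which 1 of the 4 values shown sits. For the compounds shown here, with bis(3-aminopropyl)amino on a saturated chain carbon, three bonds along the chain from an amine nitrogen, the steps are an at least 3.9-fold higher number from compound 3 to compound 4 (0.59 log units; beyond the scatter) and an at least 8.2-fold higher number from compound 2 to compound 4 (0.91 log units; beyond the scatter), both larger than any step among the earlier compounds. Those compounds showed only small changes at this part of the chain, the largest being a 2.1-fold higher number from compound 2 to compound 3 (0.33 log units; beyond the scatter), whereas this branched group moves the read-out clearly toward weaker inhibition.

Going by these compounds, how far compound 4 lies beyond its limit remains open, and the limit gives no size for the change. Also open, on these data alone, is whether a single 3-aminopropyl arm on that amine nitrogen, or a longer unbranched chain ending in one amine, would shift the number in the same direction.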